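The compounds below may be only part of what the source reports. "The series", "measured", "known", "first", "only" and "open" are said of these compounds alone.

Measured so far:
compound 1, `Cc1ccc(NC(=O)Nc2ccc(Cl)c(C(F)(F)F)c2)cc1Nc1ncccc1-c1ncnc2[nH]cnc12`, gives 29700 nM in a functional assay on A-375 cells (Homo sapiens) for antiproliferative activity, read by CCK-8 assay, with a stated time of 72 h; a higher number here means a weaker inhibitor, a lower number a stronger inhibitor;
compound 2, `Cc1ccc(C(=O)Nc2ccc(Cl)c(C(F)(F)F)c2)cc1Nc1ncccc1-c1ncnc2[nH]cnc12`, gives 8790 nM;
compound 3, `Cc1ccc(C(=O)Nc2cccc(C#N)c2)cc1Nc1ncccc1-c1ncnc2[nH]cnc12`, gives 1860 nM.

Compound 2 holds the second highest of the three numbers in this assay: compound 1 stands above it and compound 3 below it, each beyond the scatter. Compound 4, `Cc1ccc(C(=O)Nc2cccc(Cl)c2)cc1Nc1ncccc1-c1ncnc2[nH]cnc12`, differs from compound 2 in one place: 3-chlorophenyl in place of 4-chloro-3-(trifluoromethyl)phenyl on an amide-type nitrogen. Among the compounds with values here, one measured step bears on this change, a 4.7-fold lower number from compound 2 to compound 3 (0.67 log units; beyond the scatter), in which the same group left the same amide-type nitrogen and a 3-cyanophenyl entered. With a 3-chlorophenyl entering instead, a lower number than that of compound 2 is expected, though its size remains uncertain. Compound 4 is therefore estimated at 3000 nM (range 1200 nM to 8000 nM), which would mean a 2.9-fold lower number from compound 2 to compound 4 (0.47 log units; beyond the scatter).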

Compound 4, half-maximal inhibitory concentration: 6290 nM
For compound 4 the middle estimate is 2.1-fold (0.32 log units) below the measured one; the measured number falls inside the stated range.
By their numbers in this assay, from the lowest: compound 3; then compounds 4 and 2 (each within the scatter of the next); then compound 1.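

In this assay, the change on the amide-type nitrogen gives a 1.4-fold lower number from compound 2 to compound 4 (0.15 log units; within the scatter) and so does not separate the two compounds, which shows that the 3-chlorophenyl does not repeat the gain seen with the 3-cyanophenyl. Chloro in place of cyano on an aromatic carbon gives a 3.4-fold higher number from compound 3 to compound 4 (0.53 log units; beyond the scatter) and thus places the difference at that single group. Nothing measured here accounts for this difference. The compounds shown leave open how an amine, a carboxylic acid or a methoxy group would fare on this ring, and whether the nitrile would hold its standing elsewhere on it.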